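This account rests on a few compounds, and the source may have more. Where it says the series, first, only, none or still open, it means among the compounds named here.

Compound 1 `O=C(Nc1cccc(-c2oc3cc(-c4ccc(F)cc4)ccc3c(=O)c2O)c1)c1ccccc1F`: 5630 nM in a functional assay on HeLa cells (Homo sapiens) for antiproliferative activity, read by CCK-8 assay, with a stated time of 72 h; on this read-out higher numbers stand for weaker inhibition and lower numbers for stronger inhibition 
Compound 2 `Cc1cccc(C(=O)Nc2cccc(-c3oc4cc(-c5ccc(F)cc5)ccc4c(=O)c3O)c2)c1`: 6650 nM in this assay

Compound 2 gives the highest number of the two measured compounds, with compound 1 the nearest at a 1.2-fold higher number from compound 1 to compound 2 (0.07 log units; within the scatter). Compound 3 `O=C(Nc1cccc(-c2oc3cc(-c4ccc(F)cc4)ccc3c(=O)c2O)c1)c1cccc(F)c1` keeps the shared core and changes one position: fluoro in place of methyl on an aromatic carbon. Within the data shown here, the only step measured so far, a 1.2-fold higher number from compound 1 to compound 2 (0.07 log units; within the scatter), also exchanged the aryl group on the carbonyl carbon and stayed within the scatter, so the change to compound 3 is expected to produce no movement beyond the scatter, a 1.1-fold lower number from compound 2 to compound 3 (0.04 log units; within the scatter). Compound 3 is therefore estimated at 6000 nM, between 2500 nM and 14000 nM.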

Compound 3, half-maximal inhibitory concentration: 8780 nM
Beside the measured number, compound 3's estimate is 1.5-fold (0.17 log units) below it; low and high end bracket the measured number.
By their numbers in this assay, from the lowest: compounds 1, 2 and 3 (each within the scatter of the next).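

Fluoro in place of methyl on this aromatic carbon gives a 1.3-fold higher number from compound 2 to compound 3 (0.12 log units; within the scatter) in this assay, and 3-fluorophenyl in place of 2-fluorophenyl on the carbonyl carbon gives a 1.6-fold higher number from compound 1 to compound 3 (0.19 log units; within the scatter) on the same read-out. Neither exchange, of the group or of where the fluoro sits on the phenyl, separates from the scatter, so compounds 1, 2 and 3 cannot be ranked. No measurement at hand bears on these numbers. The compounds shown leave open whether an amine, a carboxylic acid or a longer chain in place of the fluoro would move the number beyond the scatter.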